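Oxazole to methylimidazole on the chain carbon

The source may hold more compounds than are shown below. What is called first, only, known or untested is meant among the compounds shown, and "the series" means these compounds.

Compound 3 `O=C(O)CC(c1ccc(OCC2COc3ccc(Cl)cc3O2)cc1)c1cnco1` gives 1030 nM in a functional assay on HEK293 cells for agonist activity at Free fatty acid receptor 1 (Homo sapiens), read by fluorescence and calcium flux, with a stated time of 10 min; on this read-out lower numbers stand for an effect already at smaller amounts and higher numbers for an effect only at larger amounts of compound. Compound 1 `O=C(O)CCc1ccc(OCC2COc3ccc(Cl)cc3O2)cc1F` gives 830 nM in this assay, which lies within the scatter of the number for compound 3. Among the compounds with values here, compound 2 `CC#CC(CC(=O)O)c1ccc(OCC2COc3ccc(Cl)cc3O2)cc1` gives 100 nM in this assay, and the single measured step at the chain carbon, a 10-fold higher number from compound 2 to compound 3 (1.01 log units; beyond the scatter), is the only change at this place seen so far. Compound 4 `Cn1cncc1C(CC(=O)O)c1ccc(OCC2COc3ccc(Cl)cc3O2)cc1` differs from compound 3 by 1-methyl-1H-imidazol-5-yl in place of 1,3-oxazol-5-yl on a saturated chain carbon bound to an aromatic carbon and a saturated chain carbon. Within the data shown here, no measured pair shows one five-membered aromatic ring exchanged for another at this place, so the measured step gives no direction for this exchange. Compound 4 is therefore expected to give about 900 nM in this assay, in the range 300 nM to 2700 nM, a step of a 1.1-fold lower number from compound 3 to compound 4 (0.06 log units; within the scatter) expected to stay within the scatter.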

Compound 4, half-maximal effective concentration: 3060 nM
Compound 4: middle estimate off by 3.4-fold (0.53 log units), on the low side; measured number outside the range, above it.
By their numbers in this assay, from the lowest: compound 2; then compounds 1 and 3 (each within the scatter of the next); then compound 4.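

In this assay the exchange of one five-membered aromatic ring for another at this saturated chain carbon is not neutral: a 3.0-fold higher number from compound 3 to compound 4 (0.47 log units; beyond the scatter) appears even though both rings count the same hydrogen-bond donors and acceptors. With a 31-fold higher number from compound 2 to compound 4 (1.49 log units; beyond the scatter) on the same carbon, prop-1-yn-1-yl keeps the lowest number against both rings. No measured data here bear on the origin of these steps.

The compounds shown do not separate the added methyl from the change of ring atoms. Going by these compounds, whether an unmethylated 1H-imidazol-5-yl or a cyclopropyl group at this place would approach compound 2 stays open.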